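The source may report more compounds than this note shows. Statements on the series, on what has been measured and on what is new or still open speak of the compounds shown alone.

In an ADME assay on Caco-2 cells (Homo sapiens) for permeability, in the apical to basolateral direction (a lower number here means that the compound crosses the layer more slowly, a higher number that the compound crosses the layer faster), compound 1 (`CC(=O)N1CCN(c2cccc(-c3ccc4c(N)ncnn34)c2)C(=O)C1(C)C`) is recorded as "not determined" (no result reported), and compound 2 (`CC(=O)N1CCN(c2cccc(-c3cc(-c4cc(C(C)C)no4)c4c(N)ncnn34)c2)C(=O)C1(C)C`) as "not determined" (no result reported). Among the measured compounds shown here, compound 3 (`CC(=O)N1CCN(c2cc(-c3cc(Cl)c4c(N)ncnn34)ccc2C(F)(F)F)C(=O)C1(C)C`) therefore holds the only number, 150 nm/s, and cannot yet be ranked against anything. Compound 4 (`CC(=O)N1CCN(c2cc(-c3cc(Cl)c4c(N)ncnn34)ccc2C#N)C(=O)C1(C)C`) alters one group of compound 3: cyano in place of trifluoromethyl on an aromatic carbon, with cyano in place of trifluoromethyl on an aromatic carbon, ortho to a large group and para to a large group. For the measured compounds named here, no measured step between closely related compounds is available to gauge this swap, so the expectation rests on the structural change alone: a small downward move in this assay, possibly no larger than the usual scatter. The expected step is a 1.6-fold lower number from compound 3 to compound 4 (0.20 log units; within the scatter). Compound 4 is estimated at 95 nm/s, with an expected range of 40 nm/s to 210 nm/s.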

Compound 4, apparent permeability: 200 nm/s
Compound 4: the middle estimate sits 2.1-fold (0.32 log units) below what was measured; low and high end bracket the measured number.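

In this assay, this first measured step at the position gives a 1.3-fold higher number from compound 3 to compound 4 (0.12 log units; within the scatter) when trifluoromethyl leaves and cyano enters, ortho to a large group and para to a large group. At this place, then, the exchange of these two groups, with their different heavy-atom counts and the hydrogen-bond acceptor that enters with cyano, does not move the number beyond the scatter. No measurement at hand accounts for this result. Going by these compounds, whether an amine or a carboxylic acid on the same aromatic carbon would also stay within the scatter remains open.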